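This account rests on a few compounds, and the source may have more. Where it says the series, first, only, none or still open, it means among the compounds named here.

Measured so far in a functional assay on MCF7 cells (Homo sapiens) for antiproliferative activity, read by MTT assay; a higher number here means a weaker inhibitor, a lower number a stronger inhibitor:
compound 1 `COc1ccc(-c2ccnc(Nc3ccc(Cl)cc3Cl)n2)cc1`: 4170 nM
compound 2 `Clc1ccc(Nc2nccc(-c3ccc(Cl)cc3Cl)n2)c(Cl)c1`: 3180 nM
compound 3 `COc1cccc(Nc2nccc(-c3ccc(F)cc3)n2)c1`: 412000 nM

Compound 3 has the highest number of the three, making it the weakest inhibitor here, and its gaps to both compound 1 and compound 2 lie beyond the scatter. Compound 4 `COc1ccc(-c2ccnc(Nc3cccc(OC)c3)n2)cc1` follows from compound 3 by a single change, methoxy in place of fluoro on an aromatic carbon. Among the measured compounds shown here, no measured pair isolates this change, so the evidence is indirect. Compound 1 also carries a methoxy group and gives 4170 nM, but it differs from compound 3 elsewhere too. Compound 2 has no methoxy group and gives 3180 nM. A moderate move toward a lower number, beyond the scatter but well short of the values of compound 1 and compound 2, therefore seems likely, though with wide uncertainty. The expected step is a 5.9-fold lower number from compound 3 to compound 4 (0.77 log units; beyond the scatter). For compound 4 the estimated value is 70000 nM, with an expected range from 10000 nM to 400000 nM.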

Compound 4, half-maximal inhibitory concentration: 3450 nM
For compound 4 the middle estimate is 20-fold (1.31 log units) above the measured one; the whole stated range lies above it.
By their numbers in this assay, from the lowest: compounds 2, 4 and 1 (each within the scatter of the next); then compound 3.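

In this assay, among the compounds shown here, the exchange of fluoro for methoxy on an aromatic carbon, para to a large group, gives a 120-fold lower number from compound 3 to compound 4 (2.08 log units; beyond the scatter) and is the first direct reading of this position. It shows that this single place can account for a large step on its own, with the rest of the structure held constant. Nothing measured on these compounds bears on why the step is so large.

The compounds shown leave open whether methoxy itself is needed here, or whether a hydroxyl, an amine or a longer chain such as ethoxy at the same place would give a similar number. As far as these compounds go, they also rest on this one pair, so it remains unknown whether the same exchange would produce a comparable step with a different group on the other aromatic ring.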